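A few compounds are considered here, and "the series" means these few. Any claim that something is new, unique, unknown or untested is made for them only; others in the source may bear on it.

Compound 1 `O=C1NC(=O)/C(=C\c2ccc(OCC(=O)N3N=C(c4ccccc4)CC3c3ccccc3Cl)cc2)S1` gives 29000 nM in an assay on cells for inhibition of histone deacetylase 8 (Homo sapiens), read by fluorescence, with a stated time of 30 min; a higher number here means a weaker inhibitor, a lower number a stronger inhibitor. Compound 2 `O=C1NC(=O)/C(=C\c2ccc(OCC(=O)N3N=C(c4ccccc4)CC3c3ccc(C(F)(F)F)cc3)cc2)S1` gives 16000 nM and compound 3 `O=C1NC(=O)/C(=C\c2ccc(OCC(=O)N3N=C(c4ccccc4)CC3c3ccc(Cl)c(Cl)c3)cc2)S1` gives 10000 nM in this assay. For the measured compounds named here, compound 1 therefore carries the highest number of the three; only the step of a 2.9-fold lower number from compound 1 to compound 3 (0.46 log units; beyond the scatter) lies beyond the scatter, while a 1.8-fold lower number from compound 1 to compound 2 (0.26 log units; within the scatter) and a 1.6-fold lower number from compound 2 to compound 3 (0.20 log units; within the scatter) remain within it. Compound 4 `O=C1NC(=O)/C(=C\c2ccc(OCC(=O)N3N=C(c4ccccc4)CC3c3ccc(Br)cc3)cc2)S1` is not yet measured; it differs from compound 1 by 4-bromophenyl in place of 2-chlorophenyl on a saturated ring carbon. The two steps that exchange the same group, a 1.8-fold lower number from compound 1 to compound 2 (0.26 log units; within the scatter) and a 2.9-fold lower number from compound 1 to compound 3 (0.46 log units; beyond the scatter), both lowered the number, one within and one modestly beyond the scatter, so a small lowering is expected for a 1.9-fold lower number from compound 1 to compound 4 (0.29 log units; within the scatter). For compound 4 the estimate in this assay is 15000 nM, with a range from 7000 nM to 32000 nM.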

Compound 4, half-maximal inhibitory concentration: 35000 nM
Compound 4: middle estimate off by 2.3-fold (0.37 log units), on the low side, outside the stated range (above it).
By their numbers in this assay, from the lowest: compounds 3, 2, 1 and 4 (each within the scatter of the next, the first and the last beyond it).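

In this assay, the change to 4-bromophenyl on this saturated ring carbon brings no lowering: a 1.2-fold higher number from compound 1 to compound 4 (0.08 log units; within the scatter) leaves it level with 2-chlorophenyl. The position does separate the groups, as a 2.2-fold higher number from compound 2 to compound 4 (0.34 log units; beyond the scatter) shows for bromo in place of trifluoromethyl on an aromatic carbon. Likewise, a 3.5-fold higher number from compound 3 to compound 4 (0.54 log units; beyond the scatter) sets 4-bromophenyl apart from 3,4-dichlorophenyl. On these data alone, whether a methoxy group or a carboxylic acid on this phenyl ring would lower the number stays open. No measurement at hand accounts for the differences among these groups.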